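A few compounds are considered here, and "the series" means these few. Any claim that something is new, unique, unknown or untested is made for them only; others in the source may bear on it.

Measured compounds in a functional assay on MCF7 cells (Homo sapiens) for cytotoxicity, read by MTT assay, with a stated time of 72 h; a higher number here means a weaker inhibitor, a lower number a stronger inhibitor:
Compound 1 `COc1cccc(/C=C2\CCC/C(=C\c3ccc(O)cc3)C2=O)c1OC` gives > 20000 nM, a limit of the assay rather than a number.
Compound 2 `COc1cc(/C=C2\CCC/C(=C\c3cccc(OC)c3OC)C2=O)ccc1O` gives 11600 nM.
Compound 3 `COc1cc(/C=C2\CCC/C(=C\c3ccc(OC)c(OC)c3)C2=O)cc(OC)c1` gives 3900 nM.

Compound 4 `COc1ccc(/C=C2\CCC/C(=C\c3cc(OC)c(OC)c(OC)c3)C2=O)cc1OC` has not yet been measured in this assay. The difference between the core of compound 1 and that of compound 3 is not broken down here. From compound 1 to compound 2 the change is methoxy in place of hydrogen on an aromatic carbon, and it gave an at least 1.7-fold lower number from compound 1 to compound 2 (0.23 log units; that floor lies within the scatter), the floor of that step resting on (the limit of > 20000 nM in this assay, at which 1 of the 3 values shown sits). From compound 3 to compound 4 the change is methoxy in place of hydrogen on an aromatic carbon, the same kind of change, though here the entering group sits ortho to two methoxy groups and para to a large group, whereas before it sat ortho to a hydroxy group and meta to a large group. For compound 4 a modest drop is expected, a 1.6-fold lower number from compound 3 to compound 4 (0.19 log units; within the scatter), because compound 2 showed an at least 1.7-fold lower number from compound 1 to compound 2 (0.23 log units; that floor lies within the scatter). Compound 4 is estimated at 2500 nM, between 800 nM and 8000 nM.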

Compound 4, half-maximal inhibitory concentration: 1600 nM
Beside the measured number, compound 4's estimate is 1.6-fold (0.19 log units) above it; low and high end bracket the measured number.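

In this assay, methoxy in place of hydrogen on an aromatic carbon gave a 2.4-fold lower number from compound 3 to compound 4 (0.39 log units; beyond the scatter), so on the core of compound 3 the change has a measurable result. Set beside the earlier step, this fits a similar result on both cores but does not establish one: the same change on two cores in this assay, an at least 1.7-fold lower number (0.23 log units; that floor lies within the scatter) from compound 1 to compound 2 and a 2.4-fold lower number (0.39 log units; beyond the scatter) from compound 3 to compound 4; the limit leaves it open whether they differ. Compound 1 stands at a limit of the assay and not at a number, so the earlier step has no fixed size: the limit of > 20000 nM in this assay, at which 1 of the 4 values shown sits.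

The compounds shown leave open how an ethoxy group or an amine would read in this assay at the place where methoxy entered compound 4. They also leave open whether the step would carry over to a core bearing a carboxylic acid.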